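The source may report more compounds than this note shows. Statements on the series, on what has been measured and on what is new or still open speak of the compounds shown alone.

Three compounds have been measured in an ADME assay on Caco-2 cells (Homo sapiens) for permeability, in the apical to basolateral direction; on this read-out lower numbers stand for lower permeability and higher numbers for higher permeability:

compound 1, `NC(=O)c1cccc(Oc2ccc3c(c2)c(=O)ncn3Cc2c(F)cc(F)cc2F)c1C(F)(F)F`, gives 1.9 10^-6 cm/s
compound 2, `O=C(Nc1cccnc1)c1cccc(Oc2ccc3c(c2)c(=O)ncn3Cc2c(F)cc(F)cc2F)c1C(F)(F)F`, gives 0.26 10^-6 cm/s
compound 3, `O=C(Nc1ccccn1)c1cccc(Oc2ccc3c(c2)c(=O)ncn3Cc2c(F)cc(F)cc2F)c1C(F)(F)F`, gives 1.2 10^-6 cm/s

Compound 3 stands second highest of these three numbers. Its nearest neighbour is compound 1: the step of a 1.6-fold lower number from compound 1 to compound 3 (0.20 log units; within the scatter) is within the scatter, so the two read alike. Its furthest neighbour is compound 2: the step of a 4.6-fold higher number from compound 2 to compound 3 (0.66 log units; beyond the scatter) is beyond the scatter. The remaining measured step, a 7.3-fold lower number from compound 1 to compound 2 (0.86 log units; beyond the scatter), is also beyond the scatter. All three steps vary only the group on the amide-type nitrogen and keep the carbamoyl group itself.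

Compound 4, `O=c1ncn(Cc2c(F)cc(F)cc2F)c2ccc(Oc3cccc(-c4ccc5[nH]ccc5c4)c3C(F)(F)F)cc12`, has not yet been measured in this assay. The change from compound 3 is 1H-indol-5-yl in place of (pyridin-2-yl)carbamoyl on an aromatic carbon. Among the compounds with values here, none of the measured steps bears on this change, since in compound 4 the whole carbamoyl group leaves and an indole enters; the data hold no such exchange. The expectation therefore rests on compound 3 and its value 1.2 10^-6 cm/s, with a wide range. The expected step in this assay is a 2.1-fold higher number from compound 3 to compound 4 (0.32 log units; beyond the scatter), an upward shift whose size is uncertain. Compound 4 is estimated at 2.5 10^-6 cm/s, within a range from 0.6 10^-6 cm/s to 10 10^-6 cm/s.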

Compound 4, apparent permeability: 10.5 10^-6 cm/s
For compound 4 the middle estimate is 4.2-fold (0.62 log units) below the measured one, outside the stated range (above it).
By their numbers in this assay, from the lowest: compound 2; then compounds 3 and 1 (each within the scatter of the next); then compound 4.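

In this assay, exchanging the carbamoyl-based group on this aromatic carbon, ortho to a trifluoromethyl group, for 1H-indol-5-yl gives an 8.8-fold higher number from compound 3 to compound 4 (0.94 log units; beyond the scatter), along with a 5.5-fold higher number from compound 1 to compound 4 (0.74 log units; beyond the scatter) and a 40-fold higher number from compound 2 to compound 4 (1.61 log units; beyond the scatter). The earlier steps shown here changed only the group on the amide nitrogen, whereas this change removes the carbamoyl group itself, and compound 4 now stands beyond the scatter above all three compounds that carry it. No measurement is available to explain this rise.

The exchange alters the ring system and removes the carbonyl and the amide link in a single step, so the compounds shown cannot separate these changes. As far as these compounds go, whether a plain phenyl ring, an amine or a carboxylic acid on this carbon would give a similar number also remains open.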